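Aryl change on the amide nitrogen: working notes

A few compounds are considered here, and "the series" means these few. Any claim that something is new, unique, unknown or untested is made for them only; others in the source may bear on it.

Measured in an in vitro ADME assay on microsomes from liver (Homo sapiens) for pharmacokinetics, read by LC-MS, with a stated time of 10 min, tested at 1 uM; a higher number here means faster removal of the compound, a lower number slower removal:
- Compound 1 `CN1C[C@H](C(=O)Nc2ccc(F)cc2)[C@@H](c2ccc(/C=C/C(=O)Nc3ccccc3N)cc2)C1`: 5 mL/min/kg
- Compound 2 `CN1C[C@H](C(=O)Nc2ccc(C(F)(F)F)cc2)[C@@H](c2ccc(/C=C/C(=O)Nc3ccccc3N)cc2)C1`: 6 mL/min/kg

Within the data shown here, compound 2, at 6 mL/min/kg, cannot be told apart from compound 1, the only other measured compound in this assay. Compound 3 `COc1cccc(NC(=O)[C@H]2CN(C)C[C@@H]2c2ccc(/C=C/C(=O)Nc3ccccc3N)cc2)c1` has not been measured. It carries 3-methoxyphenyl in place of 4-(trifluoromethyl)phenyl on an amide-type nitrogen. Among the measured compounds shown here, one measured step bears on this change: a 1.2-fold higher number from compound 1 to compound 2 (0.08 log units; within the scatter), with trifluoromethyl in place of fluoro on an aromatic carbon. That step stays within the scatter, but it involves no methoxy group, so it offers limited guidance. On these data alone, no step beyond the scatter is therefore expected, and the direction remains open. The estimated step is a 1.2-fold higher number from compound 2 to compound 3 (0.07 log units; within the scatter). Compound 3 is expected at 7 mL/min/kg, with an estimated range of 4 mL/min/kg to 13 mL/min/kg.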

Compound 3, clearance: 14 mL/min/kg
Compound 3: the middle estimate sits 2.0-fold (0.30 log units) below what was measured, outside the stated range (above it).
By their numbers in this assay, from the lowest: compounds 1 and 2 (each within the scatter of the next); then compound 3.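

The aryl group on the amide-type nitrogen can shift the number in this assay after all: 3-methoxyphenyl in place of 4-(trifluoromethyl)phenyl gives a 2.3-fold higher number from compound 2 to compound 3 (0.37 log units; beyond the scatter) and 3-methoxyphenyl in place of 4-fluorophenyl gives a 2.8-fold higher number from compound 1 to compound 3 (0.45 log units; beyond the scatter) with both steps modest but beyond the scatter. The earlier swap of fluoro for trifluoromethyl stayed within the scatter, so it gave no sign that this position could respond at all. Nothing available here accounts for the rise seen with 3-methoxyphenyl.

The compounds shown do not separate the effect of the methoxy group itself from that of where it sits on the ring, a question that 4-methoxyphenyl and 3-fluorophenyl on the same nitrogen would address. On these data alone, how a ring bearing an amine or a carboxylic acid would behave at this position also remains open.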